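Morpholin-4-yl for anilino on the thiocarbonyl carbon

The compounds below may be only part of what the source reports. "The series", "measured", "known", "first", "only" and "open" are said of these compounds alone.

Among the measured compounds shown here, in a functional assay on MGC-803 cells (Homo sapiens) for antiproliferative activity, read by MTT assay, with a stated time of 72 h (on this read-out higher numbers stand for weaker inhibition and lower numbers for stronger inhibition), compound 2 (`C/C(=N\NC(=S)Nc1ccccc1)c1cc(Cl)ccc1O`) gives 930 nM as the lower of the two numbers so far, and compound 1 (`C/C(=N\NC(=S)N1CCOCC1)c1ccccc1O`) gives 11200 nM as the higher, beyond the scatter. Compound 3 (`C/C(=N\NC(=S)N1CCOCC1)c1cc(Cl)ccc1O`) carries morpholin-4-yl in place of anilino on a thiocarbonyl carbon. Compound 1 also carries morpholin-4-yl, and its 11200 nM is the basis for expecting weaker inhibition. The expected change in this assay is an estimated step of a 3.2-fold higher number from compound 2 to compound 3 (0.51 log units; beyond the scatter) toward a higher number, probably beyond the scatter. Compound 3 is estimated at 3000 nM (800 nM to 9000 nM).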

Compound 3, half-maximal inhibitory concentration: 3060 nM
Compound 3: middle estimate off by 1.0-fold (0.01 log units), on the low side; the measured number falls inside the stated range.
By their numbers in this assay, from the lowest: compound 2; then compound 3; then compound 1.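

In this assay, with chloro held on the core, morpholin-4-yl in place of anilino on the thiocarbonyl carbon gives a 3.3-fold higher number from compound 2 to compound 3 (0.52 log units; beyond the scatter), so this position responds to the change even in the chloro series. With morpholin-4-yl held in that place, chloro in place of hydrogen on an aromatic carbon gives a 3.7-fold lower number from compound 1 to compound 3 (0.56 log units; beyond the scatter), a step of similar size in the opposite direction. Nothing available explains either step.

From the compounds shown here alone, whether the chloro step carries over with anilino on the thiocarbonyl carbon remains open. Going by these compounds, how piperazin-1-yl or dimethylamino would compare in that place also remains open.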